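Inverting the stereocentre of a urea in a whole-organism read-out

The source may hold more compounds than are shown below. What is called first, only, known or untested is meant among the compounds shown, and "the series" means these compounds.

Compound 1, `CCCCc1ccc(NC(=O)N[C@@H](C)c2ccccc2)cc1`: 98%
Compound 2, `CCCCCCCc1ccc(NC(=O)N[C@@H](C)c2ccccc2)cc1`: 100%
Compound 3, `CCOC(=O)c1ccc(NC(=O)N[C@H](C)c2ccccc2)cc1`: 101%

Among the measured compounds shown here, in an ADME assay on the whole organism with Oryza sativa as the target, tested at 0.1 uM (on this read-out lower numbers stand for a stronger effect and higher numbers for a weaker effect at the one concentration tested), compound 3 stands highest of the three numbers measured so far; its nearest neighbour is compound 2 and its furthest is compound 1, both gaps within the scatter. For the measured compounds named here, all three measured compounds therefore sit at the same level on this read-out, and no compound can be called more or less active than another.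

Compound 4, `CCOC(=O)c1ccc(NC(=O)N[C@@H](C)c2ccccc2)cc1`, has not yet been measured. The change from compound 3 to compound 4 is the two compounds have the same atoms and bonds and differ only in configuration as drawn: 1 of 1 stereo elements differ; a stereocentre at a saturated chain carbon is drawn R in compound 3 and S in compound 4. Going by the values given here, no measured step in this set alters a stereocentre; the only step available, a number 2 percentage points higher from compound 1 to compound 2 (within the scatter), concerns a chain and lies within the scatter. Among the compounds with values here, there is thus no direct precedent for the step, and the three measured values together give no sign that any change in this set moves the number beyond the scatter.

Compound 4 is therefore expected to remain at the same level, with a step of a number 1 percentage points lower from compound 3 to compound 4 (within the scatter) that is within the scatter. The estimate for compound 4 in this assay is 100%, expected to fall between 91% and 105%.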

Compound 4, a percentage reported as activity, at one concentration (the size of the read-out at that concentration, not a potency): 99%
Estimate against measurement, compound 4: 1 percentage points above, within the range that was stated.
By their numbers in this assay, from the lowest: compounds 1, 4, 2 and 3 (each within the scatter of the next).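

In this assay, among the compounds shown here, inverting the stereocentre at the saturated chain carbon gives a number 2 percentage points lower from compound 3 to compound 4 (within the scatter), the first measured step that touches this position, and nothing else changes between the two structures: the fact that compounds 3 and 4 differ only in the configuration as drawn. With the stereocentre drawn S, the aromatic substituent also leaves the read-out within the scatter, since ethoxycarbonyl in place of heptyl gives a number 1 percentage points lower from compound 2 to compound 4 (within the scatter) and ethoxycarbonyl in place of butyl gives a number 1 percentage points higher from compound 1 to compound 4 (within the scatter). Among these four compounds, then, neither this inversion in the ethoxycarbonyl compounds nor these exchanges on the aromatic carbon separates one compound from another in this assay, so the position gains a first reading but no preference for R or S.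

Whether the same inversion would also stay within the scatter with butyl or heptyl on the aromatic carbon remains open, as the only R and S pair shown carries ethoxycarbonyl. As far as these compounds go, it is also open whether a carboxylic acid or an amine on that aromatic carbon, or a different group in place of the methyl on the stereocentre, would move the number beyond the scatter.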